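The source may hold more compounds than are shown below. What is called first, only, known or untested is meant among the compounds shown, and "the series" means these compounds.

Three compounds share one core and differ only in a single group. Compound 1 `O=C(O)c1ccccc1-c1ccc(CCc2ncc(Cc3ccccc3Cl)[nH]2)cc1` carries a 2-chlorobenzyl group there, and in an in vitro functional assay on cells for agonist activity at Bombesin receptor subtype-3 (Homo sapiens), read by luminescence and calcium flux (on this read-out lower numbers stand for an effect already at smaller amounts and higher numbers for an effect only at larger amounts of compound), compound 1 gives 292 nM. Compound 2 `CC(C)(C)c1cnc(CCc2ccc(-c3ccccc3C(=O)O)cc2)[nH]1` carries a tert-butyl group instead; in this assay compound 2 gives 4330 nM. Compound 3 `N#Cc1ccccc1Cc1cnc(CCc2ccc(-c3ccccc3C(=O)O)cc2)[nH]1` carries a 2-cyanobenzyl group; in this assay compound 3 gives 5480 nM, the highest of the three numbers, though a 1.3-fold higher number from compound 2 to compound 3 (0.10 log units; within the scatter). Compound 4 `O=C(O)c1ccccc1-c1ccc(CCc2ncc(Cc3cccc(Cl)c3)[nH]2)cc1` alters one thing: 3-chlorophenyl in place of 2-cyanophenyl on a saturated chain carbon bound to an aromatic carbon. Within the data shown here, no measured step compares two chlorobenzyl groups, so the only step that bears is the earlier exchange of chloro for cyano, where a 19-fold higher number from compound 1 to compound 3 (1.27 log units; beyond the scatter). A partial reversal of that step is expected for compound 4, a 7.8-fold lower number from compound 3 to compound 4 (0.89 log units; beyond the scatter). Compound 4 is thus estimated at 700 nM, between 150 nM and 3500 nM.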

Compound 4, half-maximal effective concentration: 825 nM
Compound 4: middle estimate off by 1.2-fold (0.07 log units), on the low side; low and high end bracket the measured number.
By their numbers in this assay, from the lowest: compound 1; then compound 4; then compounds 2 and 3 (each within the scatter of the next).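

Among these compounds, with compound 4, a shift of the chloro group alone can be read for the first time: in this assay there is a 2.8-fold higher number from compound 1 to compound 4 (0.45 log units; beyond the scatter) when 3-chlorophenyl replaces 2-chlorophenyl on this saturated chain carbon. The 3-chlorobenzyl group still keeps a clear lead over the other two groups, with a 6.6-fold lower number from compound 3 to compound 4 (0.82 log units; beyond the scatter) and a 5.2-fold lower number from compound 2 to compound 4 (0.72 log units; beyond the scatter) as well. Whether 4-chlorophenyl, or a ring carrying a methoxy group or an amine, would give a lower number than compound 1 stays open, and nothing available explains why moving the chloro group changes the number.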